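A few compounds are considered here, and "the series" means these few. Any claim that something is new, unique, unknown or untested is made for them only; others in the source may bear on it.

In a functional assay for inhibition, with Homo sapiens as the target (on this read-out higher numbers stand for weaker binding and lower numbers for tighter binding), compound 1 `O=C(O)CC/C=C\CC1COC(c2ccccc2Cl)OC1c1cccnc1` gives 759 nM and compound 2 `O=C(O)CC/C=C\CC1COC(c2ccc(Cl)cc2Cl)OC1c1cccnc1` gives 891 nM while compound 3 `O=C(O)CC/C=C\CC1COC(c2ccco2)OC1c1cccnc1` gives 1260 nM and so stands within the usual scatter of both others. Compound 4 `CC(C)(Oc1ccccc1)C1OCC(C/C=C\CCC(=O)O)C(c2cccnc2)O1` differs from compound 3 at one place a group of 10 heavy atoms (9 carbon, 1 oxygen; one six-membered aromatic ring of carbon only) in place of a group of 5 heavy atoms (4 carbon, 1 oxygen; one five-membered aromatic ring with 1 hetero atom), on a saturated ring carbon on a saturated ring carbon between two ring oxygen atoms. Two measured swaps at that carbon bear on this: a 1.7-fold higher number from compound 1 to compound 3 (0.22 log units; within the scatter) and a 1.4-fold higher number from compound 2 to compound 3 (0.15 log units; within the scatter) while adding a chloro gave a 1.2-fold higher number from compound 1 to compound 2 (0.07 log units; within the scatter) and all three stay within the scatter. Among the measured compounds shown here, no measured compound carries the entering group, so the forecast is loose. The expected change is a 1.4-fold lower number from compound 3 to compound 4 (0.15 log units; within the scatter) and no shift beyond the scatter is foreseen. The estimate for compound 4 is 900 nM within a range of 300 nM to 2700 nM for now.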

Compound 4, dissociation constant: 75.9 nM
The estimate for compound 4 lay 12-fold (1.07 log units) above the measured number; measured number below the stated range.
By their numbers in this assay, from the lowest: compound 4; then compounds 1, 2 and 3 (each within the scatter of the next).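

At the saturated ring carbon between two ring oxygen atoms, the three earlier groups stayed within the scatter of one another in this assay, so this position had seemed insensitive to its group. The group of 10 heavy atoms breaks that picture, beyond the scatter against each earlier compound (a 17-fold lower number from compound 3 to compound 4 (1.22 log units; beyond the scatter); a 12-fold lower number from compound 2 to compound 4 (1.07 log units; beyond the scatter); a 10-fold lower number from compound 1 to compound 4 (1.00 log units; beyond the scatter)). Nothing measured here explains this step.

Which part of the entering group matters stays open. A benzyl or phenoxymethyl group at that carbon would help separate the roles of its oxygen and its two methyl groups.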